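This account rests on a few compounds, and the source may have more. Where it says the series, first, only, none or still open, it means among the compounds named here.

In a toxicity assay on Huh-7.5 cells (Homo sapiens) for cytotoxicity, read by MTT assay, with a stated time of 96 h (on this read-out lower numbers stand for higher toxicity in this test and higher numbers for lower toxicity in this test), compound 1 `CN(C)CCN(C)c1ccc(C#N)c(CN2CCN(C(c3ccc(Cl)cc3)c3ccc(Cl)cc3)CC2)c1` gives 3330 nM, compound 2 `CN(C)CCN(C)c1ccc(C#N)c(CN2CCN(C(c3ccccc3)c3ccc(Cl)cc3)CC2)c1` gives 5660 nM and compound 3 `CN(C)CCN(C)c1ccc(C#N)c(CN2CCN([C@H](c3ccccc3)c3ccc(Cl)cc3)CC2)c1` gives 8230 nM. Compound 2 therefore stands within the scatter of both other compounds. Compound 4 `CN(C)CCN(C)CCN(C)c1ccc(C#N)c(CN2CCN(C(c3ccccc3)c3ccc(Cl)cc3)CC2)c1` differs from it as follows: (dimethylamino)methyl in place of hydrogen on a saturated chain carbon bound to an amine nitrogen. Cut one bond further out, this reads as 2-(dimethylamino)ethyl in place of methyl.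

Going by the values given here, two measured steps bear on this change, both only indirectly. The first is a 1.7-fold higher number from compound 1 to compound 2 (0.23 log units; within the scatter), with hydrogen in place of chloro on an aromatic carbon. The second is a 1.5-fold higher number from compound 2 to compound 3 (0.16 log units; within the scatter), which rests on (the fact that one of compounds 2 and 3 is drawn with a defined configuration and the other without, at the place where they differ). Both steps lie within the scatter, and neither alters the chain that changes here, so the series gives no measured size for this change. With only these small steps as a guide, no step beyond the scatter and no firm direction is expected in this assay, though the uncertainty is wide. The expected step is a 1.1-fold lower number from compound 2 to compound 4 (0.05 log units; within the scatter). The estimated value for compound 4 is 5000 nM, with an expected range from 2000 nM to 12000 nM.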

Compound 4, half-maximal cytotoxic concentration: 6340 nM
For compound 4 the middle estimate is 1.3-fold (0.10 log units) below the measured one; low and high end bracket the measured number.
By their numbers in this assay, from the lowest: compounds 1, 2, 4 and 3 (each within the scatter of the next, the first and the last beyond it).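

In this assay, the change gives a 1.1-fold higher number from compound 2 to compound 4 (0.05 log units; within the scatter), the only measured change in this chain among the compounds shown. On the core of compound 2, then, the saturated chain carbon bound to an amine nitrogen accepts (dimethylamino)methyl in place of hydrogen with no step beyond the scatter, and the read-out gives no direction for this change. Nothing available on the series explains this result.

From the compounds shown here alone, it remains open whether a carboxylic acid in place of the dimethylamino of the 2-(dimethylamino)ethyl chain, or a longer chain such as 3-(dimethylamino)propyl, would stay within the scatter of compound 2 in this assay. Also open, going by these compounds, is whether the same small step would hold with the two chloro groups of compound 1 or the defined configuration of compound 3.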